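Removing the pentyl from selenium: compound 3 to compound 4

This account rests on a few compounds, and the source may have more. Where it says the series, first, only, none or still open, it means among the compounds named here.

In a functional assay on HT-29 cells (Homo sapiens) for cytotoxicity, read by MTT assay, with a stated time of 72 h (on this read-out higher numbers stand for weaker inhibition of growth and lower numbers for stronger inhibition of growth), compound 3 `CCCCC[Se]c1nc(NCc2ccccc2)c2ccccc2n1` gives only a limit of the assay, > 100000 nM; no number stands for it. Compound 2 `Sc1nc(NCc2ccccc2)c2ccccc2n1`, which carries a free thiol on the same aromatic carbon, gives 63500 nM in this assay. Among the compounds with values here, the one measured step that touches this position is an at least 1.5-fold higher number from compound 2 to compound 3 (0.19 log units; that floor lies within the scatter); its floor lies within the scatter, so neither size nor direction of that step is settled. Compound 1 `COc1ccc(CNc2nc([SeH])nc3ccccc23)cc1`, a selenol whose benzyl carries a methoxy, gives only a limit of the assay, > 100000 nM. Where most of the series sits is told by the limit of > 100000 nM in this assay, at which 2 of the 3 values shown sit.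

Compound 4 `[SeH]c1nc(NCc2ccccc2)c2ccccc2n1` differs from compound 3 by hydrogen in place of pentyl on a selenium. Within the data shown here, the closest measured relative is compound 1, which holds the same selenol and sits at the limit; compound 2, with a thiol in that place, is the only compound with a number, and the step from it to compound 3 is not beyond the scatter. No step beyond the scatter can therefore be expected from compound 3 to compound 4, and the step the estimate implies is a number no higher from compound 3 to compound 4 (the limit leaves the size open). Compound 4 is expected to give about 100000 nM, within 40000 nM to 250000 nM, and most likely only a limit again.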

Compound 4, concentration for total growth inhibition: > 100000 nM
Compound 4 ended at the assay's limit (the forecaster's own chance of this, stated with the estimate: 65%); the middle value sits exactly at the limit.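

In this assay, compound 4 pairs directly with compound 2, which isolates selenium against sulfur on the aromatic carbon: the exchange gives an at least 1.5-fold higher number from compound 2 to compound 4 (0.19 log units; that floor lies within the scatter), so neither its size nor its direction is settled. The steps to compound 4 from compound 3 and from compound 1 each join two limits and cannot be read, so neither hydrogen in place of pentyl on a selenium nor hydrogen in place of methoxy on an aromatic carbon can be given a size. The free selenol, the pentyl on selenium and the methoxy-bearing selenol all sit at the limit, with compound 2 the only compound carrying a number, and the position is now described by a ceiling rather than a trend: the limit of > 100000 nM in this assay, at which 3 of the 4 values shown sit.

Going by these compounds, whether any group on this carbon brings a value clearly under that limit remains open, for instance an amine, a carboxylic acid or a methyl on selenium. A pentyl on sulfur would also be informative, since it would show whether the chain or the selenium accompanies the move to the limit.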